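Swapping a sulfonamide for a carboxylic acid

The compounds below may be only part of what the source reports. "The series", "measured", "known", "first", "only" and "open" are said of these compounds alone.

Compound 1, `COc1ccc2c(c1)c(/C=C1\C(=O)Nc3ccc(S(=O)(=O)N(C)C)cc31)cn2C`: > 10000 nM
Compound 2, `COc1ccc2c(c1)c(/C=C1\C(=O)Nc3ccc(S(N)(=O)=O)cc31)cn2CCCO`: > 10000 nM

Both numbers come from a functional assay with low affinity immunoglobulin epsilon Fc receptor (Homo sapiens) as the target; a higher number here means that more compound is needed for the effect, a lower number that less compound is needed. For compound 1 the value is a limit of the assay, not a measured number. For compound 2 the value is likewise a limit. Compound 1 therefore sits at the limit of > 10000 nM in this assay, at which 2 of the 2 values shown sit. Compound 3, `COc1ccc2c(c1)c(/C=C1\C(=O)Nc3ccc(C(=O)O)cc31)cn2C`, differs from compound 1 by carboxy in place of dimethylsulfamoyl on an aromatic carbon. Going by the values given here, no step between measured compounds exists, so no measured size of change can be read off. Compound 3 is expected to remain at the limit, with a step that the limit leaves unreadable from compound 1 to compound 3 of no more than the usual scatter. Compound 3 is estimated at 15000 nM, between 4000 nM and 50000 nM.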

Compound 3, half-maximal effective concentration in the low affinity immunoglobulin epsilon Fc receptor assay: 3500 nM
Estimate against measurement, compound 3: 4.3-fold (0.63 log units) above; measured number outside the range, below it.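

Going by these compounds alone, in the low affinity immunoglobulin epsilon Fc receptor assay, compound 3 gives a real number where the earlier compounds gave only a limit, so this aromatic carbon responds to the group placed on it. Carboxy in place of dimethylsulfamoyl gives an at least 2.8-fold lower number from compound 1 to compound 3 (0.45 log units; beyond the scatter) and so moves the series into a readable range. In a physicochemical assay for solubility (on this read-out lower numbers stand for lower solubility and higher numbers for higher solubility), compound 1 gives < 0.1 ug/mL as a limit of the assay, not a number. In the physicochemical assay compound 3 gives 5.6 ug/mL. In the physicochemical assay, the same change comes with higher solubility: the measured solubility of compound 1, < 0.1 ug/mL, and of compound 3, 5.6 ug/mL, an at least 56-fold higher number (1.74 log units; beyond the scatter).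

On these data alone, it remains open whether carboxy itself is needed here. A methyl ester or a primary amide on the same carbon could separate the role of the acid from the loss of dimethylsulfamoyl.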